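Methylamino in place of methyl: one open step

This account rests on a few compounds, and the source may have more. Where it says the series, first, only, none or still open, it means among the compounds named here.

Compound 1 `Cc1cc2c(F)c(Oc3ncnc(N)c3/C=N/OCc3ccccc3)ccc2[nH]1` gives 311 nM
Compound 2 `CCCO/N=C/c1c(N)ncnc1Oc1ccc2[nH]c(C)cc2c1F` gives 30 nM

Among the measured compounds shown here, in a functional assay on HCT-116 cells (Homo sapiens) for antiproliferative activity (on this read-out lower numbers stand for stronger inhibition and higher numbers for weaker inhibition), compound 2 gives 30 nM as the lower of the two numbers so far, and its gap to compound 1 lies beyond the scatter. Compound 3 `CNCCO/N=C/c1c(N)ncnc1Oc1ccc2[nH]c(C)cc2c1F` keeps all of compound 2 except one group (methylamino in place of methyl on a saturated chain carbon, two bonds along the chain from an oxygen on an unsaturated carbon) with methylamino in place of methyl on a saturated chain carbon, two bonds along the chain from an oxygen on an unsaturated carbon. For the measured compounds named here, the only measured step that bears on this is a 10-fold lower number from compound 1 to compound 2 (1.02 log units; beyond the scatter) with ethyl in place of phenyl on a saturated chain carbon bound to an oxygen. It shows that the number can move strongly when this chain changes, but it is a different change and gives no direction for methylamino. The expected step in this assay is a 1.5-fold higher number from compound 2 to compound 3 (0.18 log units; within the scatter) and so none beyond the scatter is foreseen, only a slight lean to a higher number. The estimate for compound 3 is 45 nM with an expected range from 12 nM to 170 nM for repeated measurements.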

Compound 3, half-maximal inhibitory concentration: 3010 nM
For compound 3 the middle estimate is 67-fold (1.83 log units) below the measured one; the measured number lies above the stated range.
By their numbers in this assay, from the lowest: compound 2; then compound 1; then compound 3.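

In this assay, this end of the chain turns out to be very sensitive to a small exchange: swapping methyl for methylamino gives a 100-fold higher number from compound 2 to compound 3 (2.00 log units; beyond the scatter) and takes the chain from propoxy to 2-(methylamino)ethoxy. Among the compounds shown here, the earlier pair showed only that the number moves when phenyl gives way to ethyl, whereas compound 3 shows that a chain of similar length can still lose nearly all of the gain, and (methylamino)methyl in place of phenyl gives a 9.7-fold higher number from compound 1 to compound 3 (0.99 log units; beyond the scatter) as well. Nothing measured here gives a reason for the size of these steps.

From the compounds shown here alone, whether a hydroxy, methoxy or dimethylamino group at this place would track compound 2 or compound 3 stays open. So does whether a longer chain, such as butyl, would keep the number of compound 2.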